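This account rests on a few compounds, and the source may have more. Where it says the series, first, only, none or still open, it means among the compounds named here.

Compound 1 `COC(=O)C1=C(C)N=C(C)/C(=C(\O)OC)C1c1ccccc1Cl` gives the lowest of the three numbers in a functional assay (muscle tissue) with Cavia porcellus as the target (a higher number here means that more compound is needed for the effect, a lower number that less compound is needed), at 2.19 nM. Compound 2 `COC(=O)C1=C(C)N=C(C)/C(=C(\O)OC)C1c1cccc(I)c1` gives 41.7 nM in this assay, and compound 3 `COC(=O)C1=C(C)N=C(C)/C(=C(\O)OC)C1c1cccc(C)c1` gives 110 nM. Compound 4 `COC(=O)C1=C(C)N=C(C)/C(=C(\O)OC)C1c1ccc(C#N)cc1` differs from compound 1 in one place: 4-cyanophenyl in place of 2-chlorophenyl on a saturated ring carbon. Within the data shown here, two measured steps bear on this change, both of them leaving the same 2-chlorophenyl group: a 19-fold higher number from compound 1 to compound 2 (1.28 log units; beyond the scatter) and a 50-fold higher number from compound 1 to compound 3 (1.70 log units; beyond the scatter). Each gave a large rise in the number. Among the measured compounds shown here, no measured compound carries a 4-cyanophenyl group, so the size of the step can only be judged from those two. A large rise in this assay is therefore expected for compound 4, a 140-fold higher number from compound 1 to compound 4 (2.14 log units; beyond the scatter). Compound 4 is estimated at 300 nM, with a range from 50 nM to 2000 nM.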

Compound 4, half-maximal effective concentration: 3470 nM
For compound 4 the middle estimate is 12-fold (1.06 log units) below the measured one; the measured number lies above the stated range.
By their numbers in this assay, from the lowest: compound 1; then compound 2; then compound 3; then compound 4.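

In this assay the 4-cyanophenyl group, on the saturated ring carbon, gives the largest rise yet from the 2-chlorophenyl group (a 1600-fold higher number from compound 1 to compound 4 (3.20 log units; beyond the scatter)). It also stands clearly apart from both earlier replacements (a 32-fold higher number from compound 3 to compound 4 (1.50 log units; beyond the scatter); an 83-fold higher number from compound 2 to compound 4 (1.92 log units; beyond the scatter)), so the range at this position is much wider than compounds 1 to 3 showed. No measured evidence accounts for this rise. Open, from the compounds shown here alone, is whether the nitrile itself or its place on the phenyl ring sets the number. Also open, going by these compounds, is how a phenyl group bearing an amine or a carboxylic acid would compare.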